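One Carbon Shorter: Predicting Compound 4

The source may hold more compounds than are shown below. What is called first, only, known or untested is meant among the compounds shown, and "the series" means these compounds.

Compound 1 `CC1=C(C(=O)OCc2ccccc2)C(c2cc([N+](=O)[O-])ccc2O)C2=C(CCC(C)(C)C2=O)N1` gives 70%
Compound 2 `CCOC(=O)C1=C(C)NC2=C(C(=O)C(C)(C)CC2)C1c1cc([N+](=O)[O-])ccc1O` gives 70%
Compound 3 `CC1=C(C(=O)OCC(C)C)C(c2cc([N+](=O)[O-])cc(Br)c2O)C2=C(CC(C)(C)CC2=O)N1` gives 70%

All three compounds were tested in an assay for inhibition of Voltage-dependent L-type calcium channel subunit alpha-1C (Rattus norvegicus), read by patch clamp, tested at 10 uM (a lower number here means less inhibition, a higher number more inhibition at the concentration tested (going by the name of the read-out)), and on the numbers shown compound 2 sits level with both neighbours: compound 1 reads the same as compound 2, and compound 3 reads the same as compound 2 as well, so no compound's number can be called higher or lower than another's here.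

Compound 4 `COC(=O)C1=C(C)NC2=C(C(=O)C(C)(C)CC2)C1c1cc([N+](=O)[O-])ccc1O` is the untested member of the set. It differs from compound 2 in one place, (hydrogen in place of methyl on a saturated chain carbon bound to an oxygen next to a carbonyl group). Among the measured compounds shown here, the only measured step that touches the same place is no change at the digits printed from compound 1 to compound 2 (within the scatter), where a much larger group was swapped out on that same saturated chain carbon bound to an oxygen next to a carbonyl group without moving the read-out. Removing one further carbon at the same spot is therefore expected to give a step of no change at the digits printed from compound 2 to compound 4 (within the scatter), that is, none beyond the scatter. Compound 4 is accordingly estimated at 70%, with a range from 55% to 85%.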

Compound 4, a percentage reported as inhibition, at one concentration (the size of the read-out at that concentration, not a potency): < 30%
Compound 4: a limit, no number; the forecaster's own chance of this, stated with the estimate: 0%; middle value at least 40 percentage points from the limit.
By their numbers in this assay, from the lowest: compounds 1, 2 and 3 (each within the scatter of the next). At a limit, below all of these: compound 4.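

Cutting ethoxycarbonyl to methoxycarbonyl removes a single carbon, yet it gives a number at least 40 percentage points lower from compound 2 to compound 4 (beyond the scatter), so this place on the chain is far less forgiving than the earlier compounds suggested. The larger comparison, hydrogen in place of phenyl, gives a number at least 40 percentage points lower from compound 1 to compound 4 (beyond the scatter), whereas the earlier swap of phenyl for methyl gave no change at the digits printed from compound 1 to compound 2 (within the scatter), so in these three compounds the read-out holds with the two longer groups and is lost only with the shortest. In this assay compound 4 gives < 30%, which is a limit and not a number, and it stands alone there: the limit of < 30% in this assay, at which 1 of the 4 values shown sits.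

As far as these compounds go, whether a propyl chain would read like the ethoxycarbonyl compound, or a carboxylic acid or an amide like the methoxycarbonyl one, remains open. The reason for the loss also remains open, and so does its true size.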